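The Same Amide Change on a Different Core

The source may report more compounds than this note shows. Statements on the series, on what has been measured and on what is new or still open speak of the compounds shown alone.

Of the compounds shown here, three sharing one scaffold have been tested for antiproliferative activity. Compound 1 `CN1CCC(NC(=O)c2ccc(Cn3nc(-c4cnn(C)c4)c4ccccc4c3=O)cc2)CC1` carries a 1-methylpiperidin-4-yl group on the amide nitrogen, and in a functional assay on HepG2 cells (Homo sapiens) for antiproliferative activity, read by MTT assay, with a stated time of 72 h (on this read-out higher numbers stand for weaker inhibition and lower numbers for stronger inhibition), compound 1 gives 47300 nM. Compound 2 `Cn1cc(-c2nn(Cc3ccc(C(=O)NC4CCCC4)cc3)c(=O)c3ccccc23)cn1` replaces that group with cyclopentyl, and in this assay compound 2 gives 84300 nM. The change is cyclopentyl in place of 1-methylpiperidin-4-yl on an amide-type nitrogen, and it made a 1.8-fold higher number from compound 1 to compound 2 (0.25 log units; within the scatter).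

Compound 3 `Cc1noc(C)c1-c1nn(Cc2ccc(C(=O)NC3CCN(C)CC3)cc2)c(=O)c2ccccc12` keeps the 1-methylpiperidin-4-yl amide of compound 1 but differs in the core: 3,5-dimethyl-1,2-oxazol-4-yl in place of 1-methyl-1H-pyrazol-4-yl on an aromatic carbon. In this assay compound 3 is reported only as a limit of the assay, > 100000 nM. Measured against compound 1, this core change made an at least 2.1-fold higher number from compound 1 to compound 3 (0.32 log units; beyond the scatter).

Compound 4 `Cc1noc(C)c1-c1nn(Cc2ccc(C(=O)NC3CCCC3)cc2)c(=O)c2ccccc12` has not been measured. It stands to compound 3 as compound 2 stands to compound 1: cyclopentyl in place of 1-methylpiperidin-4-yl on an amide-type nitrogen. The place is the same in both pairs, so this is the same change, occurring in two pairs among the compounds shown.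

The step from compound 3 to compound 4 is expected to be small, close to nothing or mildly weakening, because the same change gave a 1.8-fold higher number from compound 1 to compound 2 (0.25 log units; within the scatter). Since compound 3 already sits at the limit of > 100000 nM in this assay, at which 1 of the 3 values shown sits, compound 4 is likewise expected to reach only the limit. This expectation corresponds to a step that the limit leaves unreadable from compound 3 to compound 4. In this assay compound 4 is estimated at 180000 nM, between 80000 nM and 500000 nM.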

Compound 4, half-maximal inhibitory concentration: > 100000 nM
Compound 4 was reported as a limit (the forecaster's own chance of this, stated with the estimate: 80%); the middle value does not contradict the limit.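

In this assay compound 3 and compound 4 are both reported only as limits, so the step between them cannot be read, and the series does not show whether cyclopentyl in place of 1-methylpiperidin-4-yl behaves on this core as it did on the core of compound 1. The core change, read on the cyclopentyl amide, gave an at least 1.1-fold higher number from compound 2 to compound 4 (0.07 log units; that floor lies within the scatter), and beside its counterpart on the 1-methylpiperidin-4-yl amide it reads: the same change on two cores in this assay, an at least 2.1-fold higher number (0.32 log units; beyond the scatter) from compound 1 to compound 3 and an at least 1.1-fold higher number (0.07 log units; that floor lies within the scatter) from compound 2 to compound 4; the limit leaves it open whether they differ What the pair does show is only that compounds with either amide group and the 3,5-dimethyl-1,2-oxazol-4-yl group stand at the limit, which is no evidence that the amide change does nothing on that core: the limit of > 100000 nM in this assay, at which 2 of the 4 values shown sit.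

The compounds shown leave open whether another amide group, such as a 2-(morpholin-4-yl)ethyl chain or a 4-hydroxycyclohexyl group, would give a readable value alongside the 3,5-dimethyl-1,2-oxazol-4-yl group. They also leave open how a plain phenyl group in the place of 1-methyl-1H-pyrazol-4-yl would read with either amide, and so whether the amide change can be followed on any further core.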